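Moving the nitrile on the cyanophenyl group of compound 1

The source may report more compounds than this note shows. Statements on the series, on what has been measured and on what is new or still open speak of the compounds shown alone.

Of the compounds shown here, three have been measured in a functional assay on DU-145 cells (Homo sapiens) for antiproliferative activity, read by MTT assay, with a stated time of 72 h (a lower number here means a stronger inhibitor, a higher number a weaker inhibitor), so far.

Compound 1 `COc1cc2c(Nc3ccc(C#N)cc3)ncnc2cc1OCCCN1CCCCC1` gives 24400 nM
Compound 2 `COc1cc2c(Nc3ccc(C#N)cc3)ncnc2cc1OCCCN1CCC(CO)CC1` gives 53200 nM
Compound 3 `COc1cc2c(Nc3ccc(C#N)cc3)ncnc2cc1OCCCN1CCC(c2ccccc2)CC1` gives 6790 nM

Compound 1 stands in the middle of these three numbers. Its nearest neighbour has the higher number (a 2.2-fold higher number from compound 1 to compound 2 (0.34 log units; beyond the scatter)), and the lowest number lies further off (a 3.6-fold lower number from compound 1 to compound 3 (0.56 log units; beyond the scatter)).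

Compound 4 `COc1cc2c(Nc3ccccc3C#N)ncnc2cc1OCCCN1CCCCC1` has the same atoms as compound 1, joined differently, with 2-cyanophenyl in place of 4-cyanophenyl on a nitrogen on an aromatic ring. Among the measured compounds shown here, none of the measured steps touches this group. All three change a saturated ring carbon, and even the widest of them (a 7.8-fold lower number from compound 2 to compound 3 (0.89 log units; beyond the scatter)) is modest. They bear on the question only by showing how far the numbers move within this small set. For the measured compounds named here, no measured compound carries 2-cyanophenyl, so the data give no direction for this change. A step beyond the scatter cannot be ruled out, but none is expected in this assay on this evidence. The estimated step is a 1.2-fold higher number from compound 1 to compound 4 (0.09 log units; within the scatter) and remains only an expectation. For compound 4 the expected value is 30000 nM (estimated range 10000 nM to 80000 nM).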

Compound 4, half-maximal inhibitory concentration: 15300 nM
The estimate for compound 4 lay 2.0-fold (0.29 log units) above the measured number, and the stated range covers the measured number.
By their numbers in this assay, from the lowest: compound 3; then compounds 4 and 1 (each within the scatter of the next); then compound 2.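

Among the compounds shown here, compound 4 is the first compound here to change the group on a nitrogen on an aromatic ring rather than a saturated ring carbon, and in this assay 2-cyanophenyl in place of 4-cyanophenyl gives a 1.6-fold lower number from compound 1 to compound 4 (0.20 log units; within the scatter). This rearrangement of the same atoms stays within the scatter, whereas the steps at the saturated ring carbon lie beyond it, among them a 2.2-fold higher number from compound 1 to compound 2 (0.34 log units; beyond the scatter) and a 3.6-fold lower number from compound 1 to compound 3 (0.56 log units; beyond the scatter), so these two placements of the nitrile are not told apart by this assay. No measurement available here accounts for this result.

The compounds shown leave open whether a plain phenyl, or a chlorine or methoxy group in place of the nitrile, would also leave the number within the scatter of compound 1. They also leave open whether 2-cyanophenyl would give a similar result when combined with the hydroxymethyl group of compound 2 or the phenyl group of compound 3.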